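Swapping a Benzyl Arm for a Thiophene-Bearing Branch

The source may report more compounds than this note shows. Statements on the series, on what has been measured and on what is new or still open speak of the compounds shown alone.

Of the compounds shown here, three share a common core and have been tested in an assay on HEK293 cells for agonist activity at transient receptor potential cation channel subfamily M member 8 (Homo sapiens), read by fluorescence and calcium flux, with a stated time of 15 min; a lower number here means that less compound is needed, a higher number that more compound is needed for the effect. Compound 1 `CCN(Cc1ccc(C)s1)C(=O)COc1ccc(C)cc1` gives 178 nM. Compound 2 `Cc1ccc(OCC(=O)N(Cc2cccs2)C2CCCCC2)cc1` gives 40000 nM. Compound 3 `CCN(Cc1ccccc1)C(=O)COc1ccc(C)cc1` gives 1880 nM, the second highest of the three numbers: compound 1 lies well below it, and compound 2 well above it.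

Within the data shown here, the one measured step that bears on the next change is an 11-fold higher number from compound 1 to compound 3 (1.02 log units; beyond the scatter), where phenyl replaced 5-methylthiophen-2-yl on a saturated chain carbon bound to an amide-type nitrogen.

Compound 4 `CCN(C(=O)COc1ccc(C)cc1)C(C)c1cccs1` reverses part of that move: 1-(thiophen-2-yl)ethyl in place of benzyl on an amide-type nitrogen. The thiophene ring comes back, though without the methyl on the ring, and a methyl now sits on the chain carbon instead. Compound 2 also carries a thiophene arm yet gives a high number, but it differs from compound 3 in more than one place, so its value only shows that a thiophene alone does not guarantee a low number. Given the size of the step from compound 1 to compound 3, a step down is expected for compound 4, of about a 4.2-fold lower number from compound 3 to compound 4 (0.62 log units; beyond the scatter), likely somewhat smaller than the step that removed the thiophene. Compound 4 is therefore estimated at 450 nM, with a range from 120 nM to 1800 nM.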

Compound 4, half-maximal effective concentration: "not active" (no number reported)
The entry for compound 4 holds no number; there is nothing to compare the estimate with.
By their numbers in this assay, from the lowest: compound 1; then compound 3; then compound 2.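

Among these compounds, compound 4 is recorded as not active, with no number, so no step from compound 3 to compound 4 can be read. Nothing measured here offers an explanation. The compounds shown leave open whether the thiophene ring or the methyl on the chain carbon goes with this result.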